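A few compounds are considered here, and "the series" means these few. Any claim that something is new, unique, unknown or untested is made for them only; others in the source may bear on it.

Compound 1 `O=c1ccc(-c2ccc3cn[nH]c3c2)cn1Cc1ccccc1C(F)(F)F` stands alone in this set as the compound with an actual number rather than a limit. In an assay for inhibition of MAP kinase-interacting serine/threonine-protein kinase 1 (Homo sapiens), read by luminescence and ADP-Glo, with a stated time of 2 h (on this read-out lower numbers stand for stronger inhibition and higher numbers for weaker inhibition), compound 1 gives 133 nM. Compound 2 `Cn1cc2ccc(-c3ccc(=O)n(Cc4ccccc4)c3)cc2n1` reaches only the edge of what the measurement reports: in this assay compound 2 gives > 2000 nM, which is a limit and not a number. Compound 2 sits at the limit of > 2000 nM in this assay, at which 1 of the 2 values shown sits. Compound 2 differs from compound 1 in more than one place. Among the compounds with values here, the two values show only that one compound gives a number and the other does not. Compound 3 `O=c1ccc(-c2ccc3cn[nH]c3c2)cn1Cc1ccccc1Cl` has not been measured yet; it differs from compound 1 by chloro in place of trifluoromethyl on an aromatic carbon, ortho to a large group. Within the data shown here, no measured pair shows this exchange. The step expected from a 1.5-fold higher number from compound 1 to compound 3 (0.18 log units; within the scatter) is small, toward weaker inhibition if anything, and within the usual scatter. Compound 3 is therefore expected near 200 nM, between 70 nM and 600 nM.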

Compound 3, half-maximal inhibitory concentration: 80 nM
Beside the measured number, compound 3's estimate is 2.5-fold (0.40 log units) above it; the measured number falls inside the stated range.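

The set now holds its first pair of compounds that differ in one place, and in this assay the exchange of trifluoromethyl for chloro on an aromatic carbon, ortho to a large group, gives a 1.7-fold lower number from compound 1 to compound 3 (0.22 log units; within the scatter). On this read-out the position takes chloro as well as trifluoromethyl, and the two groups cannot be told apart. Nothing in the data shown gives a reason for this result.

Compound 2, whose > 2000 nM is a limit and not a number, differs from compound 1 in more than one place, so it cannot show what this position contributes on its own. Also open, as far as these compounds go, is how the shared core would read with an amine, a methoxy group or a carboxylic acid at this place, or with only hydrogen there.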